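Swapping Methyl for Chloro on a Methoxy-Bearing Core

The source may hold more compounds than are shown below. What is called first, only, known or untested is meant among the compounds shown, and "the series" means these compounds.

Three close relatives of one compound have been tested in a functional assay on A549 cells (Homo sapiens) for cytotoxicity, read by MTT assay, with a stated time of 48 h; on this read-out lower numbers stand for stronger inhibition and higher numbers for weaker inhibition. Compound 1 `CCOC(=O)c1c(-c2cc3ccccc3oc2=O)nn(-c2cccc(C)c2)c1C(=O)OCC` gives 52000 nM. Compound 2 `CCOC(=O)c1c(-c2cc3ccccc3oc2=O)nn(-c2cccc(Cl)c2)c1C(=O)OCC` differs from compound 1 by chloro in place of methyl on an aromatic carbon; in this assay compound 2 gives 28000 nM, and the result is a 1.9-fold lower number from compound 1 to compound 2 (0.27 log units; within the scatter). Compound 3 `CCOC(=O)c1c(-c2cc3cc(OC)ccc3oc2=O)nn(-c2cccc(C)c2)c1C(=O)OCC` carries a changed core, differing from compound 1 by methoxy in place of hydrogen on an aromatic carbon, and in this assay compound 3 gives 102000 nM; the result is a 2.0-fold higher number from compound 1 to compound 3 (0.29 log units; within the scatter).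

Compound 4 `CCOC(=O)c1c(-c2cc3cc(OC)ccc3oc2=O)nn(-c2cccc(Cl)c2)c1C(=O)OCC` has not been measured. It is made from compound 3 by chloro in place of methyl on an aromatic carbon, the same change that turned compound 1 into compound 2, at the same place on the ring in both cases; it occurs twice among these four compounds. Among the measured compounds shown here, the only guide is the earlier outcome on the core without the methoxy group, and whether it carries over to the methoxy-bearing core of compound 3 cannot be checked from these measurements alone. The expectation for compound 4 is therefore a step of about a 1.9-fold lower number from compound 3 to compound 4 (0.27 log units; within the scatter), modelled on the earlier one, because the measured result a 1.9-fold lower number from compound 1 to compound 2 (0.27 log units; within the scatter) is the only recorded effect of this change. Compound 4 is thus estimated at 55000 nM, with a plausible range from 25000 nM to 120000 nM.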

Compound 4, half-maximal inhibitory concentration: 148000 nM
For compound 4 the middle estimate is 2.7-fold (0.43 log units) below the measured one, outside the stated range (above it).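

In this assay, putting chloro in place of methyl on the methoxy-bearing core gives a 1.5-fold higher number from compound 3 to compound 4 (0.16 log units; within the scatter), so compound 3 and compound 4 cannot be told apart, yet this step does not match the one seen on the core of compound 1: the same change on two cores in this assay, a 1.9-fold lower number (0.27 log units; within the scatter) from compound 1 to compound 2 and a 1.5-fold higher number (0.16 log units; within the scatter) from compound 3 to compound 4, 2.7-fold (0.43 log units) apart, beyond the scatter of two such steps. Read the other way round, methoxy in place of hydrogen on the chloro-bearing compounds gives a 5.3-fold higher number from compound 2 to compound 4 (0.72 log units; beyond the scatter), and this step does not match the one seen on the methyl-bearing compounds: the same change on two cores in this assay, a 2.0-fold higher number (0.29 log units; within the scatter) from compound 1 to compound 3 and a 5.3-fold higher number (0.72 log units; beyond the scatter) from compound 2 to compound 4, 2.7-fold (0.43 log units) apart, beyond the scatter of two such steps. Within these four compounds, then, the two changes do not simply add up, and the result of one change cannot be carried unaltered to the other core; but a single set of four compounds does not show why this happens, or whether it would hold on any other core.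

The compounds shown leave open how the methoxy-bearing core would respond to other groups in the place of the methyl or chloro, such as an amine, a carboxylic acid or a longer chain. They also leave open whether a hydroxy group or a fluoro group in the place of the methoxy would give the same mismatch between the two cores.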